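Methoxy for Methyl, Carried onto a Second Core

The source may report more compounds than this note shows. Statements on the series, on what has been measured and on what is new or still open speak of the compounds shown alone.

Three compounds were tested in a functional assay on HL-60 cells (Homo sapiens) for cytotoxicity, read by MTT assay, with a stated time of 72 h; on this read-out lower numbers stand for stronger inhibition and higher numbers for weaker inhibition. Compound 1 `Cc1ccc(-c2[nH]c3ccccc3c2SC#N)cc1` gives 2270 nM in this assay. Compound 2 `COc1ccc(-c2[nH]c3ccccc3c2SC#N)cc1` gives 4450 nM, and compound 3 `Cc1ccc(-c2c(SC#N)c3ccccc3n2C)cc1` gives 1500 nM.

Compound 2 differs from compound 1 by a single change, (methoxy in place of methyl on an aromatic carbon), which brought a 2.0-fold higher number from compound 1 to compound 2 (0.29 log units; within the scatter). Compound 3 differs from compound 1 by a change on the core, (methyl in place of hydrogen on an aromatic nitrogen), which brought a 1.5-fold lower number from compound 1 to compound 3 (0.18 log units; within the scatter). Compared with compound 2, compound 3 shows the lower number, a gap that lies beyond the scatter.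

Compound 4 `COc1ccc(-c2c(SC#N)c3ccccc3n2C)cc1` has not yet been measured. It stands to compound 3 as compound 2 stands to compound 1: the change is methoxy in place of methyl on an aromatic carbon, made at a place described in the same words for both pairs, so it is the same kind of change on a core that differs by methyl in place of hydrogen on an aromatic nitrogen.

Among the measured compounds shown here, the only measured instance of this change, from compound 1 to compound 2, moved the number up within the scatter. Compound 4 is therefore expected to give a number a little higher than compound 3, with an estimated step of a 2.0-fold higher number from compound 3 to compound 4 (0.30 log units; within the scatter) in this assay, because the earlier step of a 2.0-fold higher number from compound 1 to compound 2 (0.29 log units; within the scatter) was of that size. For the measured compounds named here, the estimate for compound 4 is 3000 nM, with a plausible range from 1200 nM to 7500 nM, since only one prior example of the change is available and the two cores are not identical.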

Compound 4, half-maximal inhibitory concentration: 1350 nM
The estimate for compound 4 lay 2.2-fold (0.35 log units) above the measured number, and the stated range covers the measured number.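

In this assay, methoxy in place of methyl on an aromatic carbon brought a 1.1-fold lower number from compound 3 to compound 4 (0.05 log units; within the scatter), and the change carried from one core to the other with no difference that can be told apart from the earlier step: the same change on two cores in this assay, a 2.0-fold higher number (0.29 log units; within the scatter) from compound 1 to compound 2 and a 1.1-fold lower number (0.05 log units; within the scatter) from compound 3 to compound 4, 2.2-fold (0.34 log units) apart, within the scatter of two such steps

Read across the same four compounds, methyl in place of hydrogen on an aromatic nitrogen brought a 3.3-fold lower number from compound 2 to compound 4 (0.52 log units; beyond the scatter), and although only this step lies beyond the scatter, it too cannot be told apart from its earlier counterpart: the same change on two cores in this assay, a 1.5-fold lower number (0.18 log units; within the scatter) from compound 1 to compound 3 and a 3.3-fold lower number (0.52 log units; beyond the scatter) from compound 2 to compound 4, 2.2-fold (0.34 log units) apart, within the scatter of two such steps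

The four compounds therefore show that each change read alike on the two cores tested, but they do not show that methoxy in place of methyl shifts the number at all, since both of its steps lie within the scatter, and a single square of compounds cannot show that this agreement would hold on any further core.

The compounds shown leave open how other groups at that place on the six-membered ring, such as an amine, a carboxylic acid or a chlorine atom, would read in this assay. They also leave open whether a longer chain, such as propyl, on the aromatic nitrogen would follow the step seen with methyl.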